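Pendant aryl variation in a cyclic dipeptide series

The source may hold more compounds than are shown below. What is called first, only, known or untested is meant among the compounds shown, and "the series" means these compounds.

Measured so far:
compound 1, `CCCCCCCCN1CC(=O)N(C)[C@@H](Cc2ccc(-c3cc(OC)c(OC)c(OC)c3)cc2)C1=O`, 400 nM
compound 2, `CCCCCCCCN1CC(=O)N(C)[C@@H](Cc2ccc(-c3ccc(OC)c(OC)c3)cc2)C1=O`, 3300 nM

Compound 1 carries a trimethoxyphenyl on the pendant ring; in a functional assay for agonist activity at follicle-stimulating hormone receptor (Homo sapiens), read by a luciferase reporter (on this read-out higher numbers stand for an effect only at larger amounts of compound and lower numbers for an effect already at smaller amounts), compound 1 gives 400 nM. Compound 2, `CCCCCCCCN1CC(=O)N(C)[C@@H](Cc2ccc(-c3ccc(OC)c(OC)c3)cc2)C1=O`, lacks one of those methoxy groups and in this assay compound 2 gives 3300 nM, the highest number of the two measured compounds. Among the compounds with values here, the only measured step, an 8.3-fold higher number from compound 1 to compound 2 (0.92 log units; beyond the scatter), is hydrogen in place of methoxy on an aromatic carbon.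

Compound 3, `CCCCCCCCN1CC(=O)N(C)[C@@H](Cc2ccc(-c3cc(C)c(OC)c(C)c3)cc2)C1=O`, is not yet measured. Its change from compound 2 is 4-methoxy-3,5-dimethylphenyl in place of 3,4-dimethoxyphenyl on an aromatic carbon. Within the data shown here, no measured step covers methyl in place of methoxy directly; the step from compound 1 to compound 2 shows only that removing a methoxy from the pendant ring moves the number up. Compound 3 carries the methoxy that compound 2 lacks, but as methyl rather than methoxy, and also replaces one of the methoxy groups of compound 2 by methyl. The expectation is a number between those of compound 2 and compound 1, most likely closer to compound 1, so for compound 3 the estimated step is a 4.7-fold lower number from compound 2 to compound 3 (0.67 log units; beyond the scatter). In this assay compound 3 is expected to give about 700 nM, within 150 nM to 3000 nM.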

Compound 3, half-maximal effective concentration: 1200 nM
The estimate for compound 3 lay 1.7-fold (0.23 log units) below the measured number; the measured number falls inside the stated range.
By their numbers in this assay, from the lowest: compound 1; then compound 3; then compound 2.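

Methyl on the pendant ring can stand in for methoxy without a loss in this assay: the change to 4-methoxy-3,5-dimethylphenyl gives a 2.8-fold lower number from compound 2 to compound 3 (0.44 log units; beyond the scatter) and so improves on the 3,4-dimethoxyphenyl ring, even though the entering group counts 1 hydrogen-bond acceptor and the leaving group 2. The same group still falls short of the trimethoxyphenyl ring, with a 3.0-fold higher number from compound 1 to compound 3 (0.48 log units; beyond the scatter) on that comparison, so this position now shows an order of three ring patterns and not only the effect of losing one methoxy. Nothing available explains why the dimethyl pattern lands where it does.

The compounds shown leave open whether the gain in compound 3 depends on methyl itself or on any small group filling those ring places, and a 4-methoxy-3,5-dichlorophenyl or a 3,5-dimethylphenyl ring would begin to separate these readings. Also open, on these data alone, is how far the pendant ring pattern holds with another group in place of the octyl chain, such as a shorter hexyl chain or a chain ending in an amine.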